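Swapping an Arylamine for Piperidine on a Shared Core

The compounds below may be only part of what the source reports. "The series", "measured", "known", "first", "only" and "open" are said of these compounds alone.

Measured in a functional assay on MCF7 cells (Homo sapiens) for inhibition, read by sulforhodamine B assay; a higher number here means a weaker inhibitor, a lower number a stronger inhibitor:
- compound 1, `O=C1C=C(Nc2cccc(F)c2)C(=O)c2c1nc1n2[C@H]2OC[C@@H](O)[C@H]2OC1`, gives 5500 nM
- compound 2, `CCOc1ccc(NC2=CC(=O)c3nc4n(c3C2=O)[C@H]2OC[C@@H](O)[C@H]2OC4)cc1`, gives 1430 nM

Among these two numbers compound 1 holds the highest, meaning the weaker inhibitor; its nearest neighbour is compound 2, and the step of a 3.8-fold lower number from compound 1 to compound 2 (0.59 log units; beyond the scatter) came with 4-ethoxyphenyl in place of 3-fluorophenyl on the amine nitrogen.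

Compound 3, `O=C1C=C(N2CCCCC2)C(=O)c2c1nc1n2[C@H]2OC[C@@H](O)[C@H]2OC1`, takes a different route. Its change from compound 1 is piperidin-1-yl in place of (3-fluorophenyl)amino on a double-bonded ring carbon. Here the aromatic ring and the hydrogen-bond donor both leave, and a saturated ring with a single hetero atom enters directly on the ring carbon.

Among the measured compounds shown here, the only measured step, from compound 1 to compound 2, alters substituents on an aryl ring that is kept; it does not bear on removing that ring and its amine hydrogen. No comparison of that kind exists among the measured compounds, so the direction of the step in this assay is open. A step of a 1.5-fold higher number from compound 1 to compound 3 (0.16 log units; within the scatter) is expected, with wide uncertainty. For compound 3 the estimate is 8000 nM, ranging from 2000 nM to 30000 nM.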

Compound 3, half-maximal inhibitory concentration: > 8000 nM
Compound 3 gave a limit, no number; the forecaster's own chance of this, stated with the estimate: 15%; the middle value lies on the limit itself.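

In this assay compound 3 reads as a limit of the assay and not as a number: the limit of > 8000 nM in this assay, at which 1 of the 3 values shown sits.

The step is an at least 1.4-fold higher number from compound 1 to compound 3 (0.16 log units; that floor lies within the scatter), so it gives only a floor with no upper end, and that floor alone does not separate the two compounds. Among the compounds shown here, still, this is the first look at this double-bonded ring carbon with the aromatic ring and the amine hydrogen both gone, whereas the earlier step kept an aryl ring on the amine nitrogen and changed only its substituents. Piperidin-1-yl, a non-aromatic ring with no hydrogen-bond donor, gave no sign of a stronger inhibitor than compound 1.

Compound 3 changes the aromatic ring and the amine hydrogen together, so the compounds shown leave open which of the two matters, and how far the number really rises. A cyclohexylamino group, which keeps the amine hydrogen on a non-aromatic ring, would pull those two changes apart, and a morpholin-4-yl group would test a second saturated ring attached directly at this carbon.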